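A few compounds are considered here, and "the series" means these few. Any claim that something is new, unique, unknown or untested is made for them only; others in the source may bear on it.

Measured compounds in a functional assay on MCF7 cells (Homo sapiens) for cytotoxicity, read by MTT assay, with a stated time of 72 h; on this read-out lower numbers stand for stronger inhibition and higher numbers for weaker inhibition:
compound 1 `NS(=O)(=O)c1cc(-c2nnc(Cn3cc(-c4ccccc4)nn3)o2)c(Cl)cc1SCc1ccccc1` gives 170000 nM;
compound 2 `COc1ccc(-c2cn(Cc3nnc(-c4cc(S(N)(=O)=O)c(SCc5ccccc5)cc4Cl)o3)nn2)cc1` gives 1500000 nM.

Compound 1 holds the lowest of these two numbers; its nearest neighbour is compound 2, at an 8.8-fold higher number from compound 1 to compound 2 (0.95 log units; beyond the scatter). Compound 3 `NS(=O)(=O)c1cc(-c2nnc(/C=C/c3ccc(Br)cc3)o2)c(Cl)cc1SCc1ccccc1` is not yet measured. It differs from compound 1 in one place: 2-(4-bromophenyl)ethenyl in place of (4-phenyl-1H-1,2,3-triazol-1-yl)methyl on an aromatic carbon. Within the data shown here, no measured step covers a change of this kind; the only step known, an 8.8-fold higher number from compound 1 to compound 2 (0.95 log units; beyond the scatter), concerns a methoxy group and bears on it only loosely. Lacking a closer precedent, compound 3 is expected to stay near compound 1, with a wide range: the estimate is 150000 nM, between 40000 nM and 600000 nM. That estimate means an expected 1.1-fold lower number from compound 1 to compound 3 (0.05 log units; within the scatter), within the scatter.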

Compound 3, half-maximal inhibitory concentration: 13000 nM
The estimate for compound 3 lay 12-fold (1.06 log units) above the measured number, and the stated range ends above it.
By their numbers in this assay, from the lowest: compound 3; then compound 1; then compound 2.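

In this assay, the group on the aromatic carbon of the five-membered aromatic ring tolerates a large change: 2-(4-bromophenyl)ethenyl in place of (4-phenyl-1H-1,2,3-triazol-1-yl)methyl gives a 13-fold lower number from compound 1 to compound 3 (1.12 log units; beyond the scatter). The earlier step altered only a methoxy group, whereas this one shows that activity here does not depend on keeping the triazole-bearing group. Nothing available explains this gain. As far as these compounds go, it remains open whether the bromine, the double bond or both carry the step, and how a chlorine or an amine in place of that bromine would compare.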